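The compounds below may be only part of what the source reports. "The series", "measured", "known", "first", "only" and "open" are said of these compounds alone.

Measured compounds in a functional assay on HT-29 cells (Homo sapiens) for cytotoxicity, read by MTT assay, with a stated time of 24 h, tested at 1.6 ug/mL; on this read-out lower numbers stand for a weaker effect and higher numbers for a stronger effect at the one concentration tested:

- compound 1 `Cn1c(-c2ccc(NC(=O)CSc3nc4ccccc4o3)cc2)nc(-c2ccccc2)c1-c1ccccc1` gives 41%
- compound 2 `Cn1cnnc1SCC(=O)Nc1ccc(-c2nc(-c3ccccc3)c(-c3ccccc3)n2C)cc1` gives 40.8%
- compound 3 `Cn1ccnc1SCC(=O)Nc1ccc(-c2nc(-c3ccccc3)c(-c3ccccc3)n2C)cc1` gives 23.8%

Compound 2 stands second highest of the three numbers in this assay; its value and that of compound 1 lie within the scatter of each other, as the step of a number 0.2 percentage points lower from compound 1 to compound 2 (within the scatter) shows, while compound 3 sits clearly lower, by a number 17 percentage points lower from compound 2 to compound 3 (beyond the scatter) and, from compound 1, by a number 17.2 percentage points lower from compound 1 to compound 3 (beyond the scatter).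

Compound 4 `CN(C)/C=C/N1CCN(CC(=O)Nc2ccc(-c3nc(-c4ccccc4)c(-c4ccccc4)n3C)cc2)CC1` is not yet measured. Its difference from compound 2 is 4-(2-(dimethylamino)ethenyl)piperazin-1-yl in place of (4-methyl-4H-1,2,4-triazol-3-yl)sulfanyl on a saturated chain carbon bound to a carbonyl carbon. Going by the values given here, every measured step exchanges one heteroaryl on the sulfur for another; none of them removes the sulfanyl linker or installs a piperazinyl bearing a 2-(dimethylamino)ethenyl group, so no step bears directly on this change. The measured steps only show that a swap at this position can leave the number unchanged or lower it modestly. For compound 4 the expectation is therefore a value near the middle of the measured spread, with a wide range, giving an estimated step of a number 8.8 percentage points lower from compound 2 to compound 4 (within the scatter) in this assay. Compound 4 is estimated at 32%, between 14% and 50%.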

Compound 4, a percentage reported as activity, at one concentration (the size of the read-out at that concentration, not a potency): 8%
Compound 4: the middle estimate sits 24 percentage points above what was measured, and the stated range ends above it.
By their numbers in this assay, from the lowest: compound 4; then compound 3; then compounds 2 and 1 (each within the scatter of the next).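

In this assay, 4-(2-(dimethylamino)ethenyl)piperazin-1-yl on the saturated chain carbon bound to a carbonyl carbon gives a lower number than every sulfanyl-linked heteroaryl shown: a number 32.8 percentage points lower from compound 2 to compound 4 (beyond the scatter) and a number 33 percentage points lower from compound 1 to compound 4 (beyond the scatter) and a number 15.8 percentage points lower from compound 3 to compound 4 (beyond the scatter). The earlier swaps kept the sulfur and changed only the heteroaryl, with steps no larger than modest, whereas this change removes both the sulfur and the five-membered aromatic ring or benzoxazole and can produce a large step. No measurement shown accounts for the drop. The compounds leave open whether the lower number follows from losing the sulfanyl linker, from the piperazine ring, or from the 2-(dimethylamino)ethenyl group. A 4-methylpiperazin-1-yl or a morpholin-4-yl on the same carbon would help separate these parts.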